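The compounds below may be only part of what the source reports. "The series", "measured", "known", "first", "only" and "open" are said of these compounds alone.

Measured compounds:
Compound 1, `COc1ccc(-c2cc(/C=C/C(=O)c3ccc(N)cc3)[nH]n2)cc1` — 2810 nM
Compound 2, `COc1cc(-c2cc(/C=C/C(=O)c3ccc(N)cc3)[nH]n2)cc(OC)c1OC` — 4840 nM

Both compounds were tested in a functional assay on TK-10 cells (Homo sapiens) for inhibition, read by sulforhodamine B assay, with a stated time of 48 h; a higher number here means a weaker inhibitor of growth, a lower number a stronger inhibitor of growth. Compound 1 gives 2810 nM and compound 2 gives 4840 nM. On paper compound 2 stands with the higher of the two numbers, but its gap to compound 1 lies within the usual scatter of repeated measurements, so the two cannot be told apart with confidence. The shared core carries an aromatic ring that differs only in its methoxy groups: one in compound 1, three in compound 2.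

Compound 3, `COc1ccc(-c2cc(/C=C/C(=O)c3ccc(N)cc3)[nH]n2)cc1OC`, sits between these two: hydrogen in place of methoxy on an aromatic carbon, and in full (hydrogen in place of methoxy on an aromatic carbon). Within the data shown here, no step between measured compounds in this assay is known, so the expectation rests on the two numbers alone. Removing one of the three methoxy groups is expected to move compound 3 toward compound 1 rather than away from it, and the step from compound 2 is expected to be a 1.4-fold lower number from compound 2 to compound 3 (0.14 log units; within the scatter), that is, nothing beyond the scatter. Compound 3 is estimated at 3500 nM, with a likely range from 1500 nM to 8000 nM.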

Compound 3, concentration for 50% growth inhibition: 1090 nM
Compound 3: the middle estimate sits 3.2-fold (0.51 log units) above what was measured, outside the stated range (below it).
By their numbers in this assay, from the lowest: compound 3; then compounds 1 and 2 (each within the scatter of the next).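

In this assay, taking away the methoxy group that sits ortho to a methoxy group and meta to a large group, leaving hydrogen on that aromatic carbon, gives a 4.4-fold lower number from compound 2 to compound 3 (0.65 log units; beyond the scatter), a step beyond the scatter. The reverse kind of change, methoxy in place of hydrogen on an aromatic carbon, gives a 2.6-fold lower number from compound 1 to compound 3 (0.41 log units; beyond the scatter), also beyond the scatter, so compound 3 is reached with a lower number both by losing a methoxy group from compound 2 and by gaining one on compound 1, and the effect of a methoxy group on this ring therefore depends on which other methoxy groups are present rather than simply adding up with their number. Nothing among the data shown explains why these two opposite changes both lead to a lower number.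

The compounds shown leave open whether a hydroxyl group, a fluorine atom or an ethoxy group on this same aromatic carbon would give a number closer to that of compound 3 or that of compound 2. They also leave open whether the same order would appear in cells other than those of this one assay.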